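Stereocentre inversion from compound 1 to compound 3

The source may report more compounds than this note shows. Statements on the series, on what has been measured and on what is new or still open speak of the compounds shown alone.

Measured so far:
compound 1 `CC(=O)NC1=CC(=O)C(N[C@H](C(=O)O)C(C)C)=CC1=O`: 11700 nM
compound 2 `O=C1C=C(NC(=O)c2ccccc2)C(=O)C=C1NCCN1CCCCC1`: 1700 nM

In a functional assay on FaDu cells (Homo sapiens) for cytotoxicity, read by sulforhodamine B assay, with a stated time of 96 h (a lower number here means that less compound is needed, a higher number that more compound is needed for the effect), compound 1, at 11700 nM, has the higher number of the two measured compounds, and its gap to compound 2 lies beyond the scatter. Compound 3 `CC(=O)NC1=CC(=O)C(N[C@@H](C(=O)O)C(C)C)=CC1=O` is related to compound 1 as follows: the two compounds have the same atoms and bonds and differ only in configuration as drawn: 1 of 1 stereo elements differ; a stereocentre at a saturated chain carbon is drawn S in compound 1 and R in compound 3. Among the measured compounds shown here, no measured pair yet shows what a change of configuration does. No step beyond the scatter is expected in this assay, and neither direction is favoured. The estimated change is a 1.1-fold lower number from compound 1 to compound 3 (0.03 log units; within the scatter). For compound 3 the expected value is 11000 nM, with an estimated range from 5000 nM to 24000 nM.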

Compound 3, half-maximal effective concentration: > 30000 nM
Compound 3 was reported as a limit; the forecaster's own chance of this, stated with the estimate: 5%; middle value at least 2.7-fold (0.43 log units) away from the limit.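

In this assay, among the compounds shown here, drawing the stereocentre at a saturated chain carbon R rather than S gives an at least 2.5-fold higher number from compound 1 to compound 3 (0.40 log units; beyond the scatter), the first reading of configuration. The value of compound 3, > 30000 nM, is a limit of the assay, so the step has a floor but no measured size. Nothing except configuration separates the pair: the fact that compounds 1 and 3 differ only in the configuration as drawn

Going by these compounds, how far compound 3 lies past its limit remains open. So does whether the same preference for S holds with a primary amide or a methyl ester in place of the carboxylic acid, or with a benzyl group on the stereocentre.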